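This account rests on a few compounds, and the source may have more. Where it says the series, first, only, none or still open, it means among the compounds named here.

Measured compounds and their values:

Compound 1, `CCOc1cc(CN2CCC(NC(=O)c3cncc(C)c3)CC2)cc(OCC)c1-c1ccc(F)cc1`: 4.01
Compound 2, `CCOc1cc(CN2CCC(NC(=O)c3ccc(NC)nc3)CC2)cc(OCC)c1-c1ccc(F)cc1`: 3.83

Both numbers come from a physicochemical assay for lipophilicity, read by spectrophotometry, measured as octanol-water partition, at pH 7.4; on this read-out lower numbers stand for lower lipophilicity and higher numbers for higher lipophilicity. Compound 1 and compound 2 share the same core and differ only at the amide: the step of a number 0.18 log units lower from compound 1 to compound 2 (within the scatter) is small, so the two compounds sit within the scatter of each other and neither can be ranked above the other on this assay.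

Compound 3, `CCOc1cc(CN2CCC(NC(=O)c3cncc(C)c3)CC2)cc(OCC)c1-c1ccc(OC(F)(F)F)cc1`, is not yet measured. It differs from compound 1 at the other end of the molecule, on the phenyl ring: trifluoromethoxy in place of fluoro on an aromatic carbon. Among the measured compounds shown here, no measured step touches this part of the structure; the only step known, from compound 1 to compound 2, changes the amide side and says nothing about the phenyl side. The expectation for compound 3 therefore rests on the change itself, which replaces one heavy atom with five and adds a hydrogen-bond acceptor, and is that compound 3 will read clearly higher than compound 1, a step of a number 0.89 log units higher from compound 1 to compound 3 (beyond the scatter). Compound 3 is estimated at 4.9, with a range from 4.5 to 5.3.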

Compound 3, distribution coefficient: > 4
Compound 3 gave a limit, no number; the forecaster's own chance of this, stated with the estimate: 10%; the middle value lies beyond the limit too.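

In this assay compound 3 gives > 4, which is a limit of the assay and not a number. No size can therefore be read for the step from compound 1 to compound 3. The compounds shown leave open how far trifluoromethoxy in place of fluoro changes the number in this assay, and whether that change lies beyond the scatter.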